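The source may hold more compounds than are shown below. What is called first, only, known or untested is meant among the compounds shown, and "the series" means these compounds.

Compound 1 `CCn1c(=O)/c(=C2\Sc3cc(F)ccc3N2C)s/c1=C\c1ccncc1Nc1ccccc1F`: 230 nM
Compound 2 `CCn1c(=O)/c(=C2\Sc3ccccc3N2C)s/c1=C\c1ccncc1Nc1ccccc1C`: 990 nM

Both compounds were tested in a functional assay on MCF7 cells (Homo sapiens) for inhibition; a higher number here means a weaker inhibitor, a lower number a stronger inhibitor. Of the two numbers, compound 2 stands highest; its nearest neighbour is compound 1, with a lower number, and that gap lies beyond the scatter. Compound 3 `CCn1c(=O)/c(=C2\Sc3cc(F)ccc3N2C)s/c1=C\c1ccncc1Nc1ccccc1C` is the next compound to be measured. It differs from compound 2 in one place: fluoro in place of hydrogen on an aromatic carbon. Within the data shown here, compound 1 also carries a fluoro on its fused ring system, but it differs from compound 2 elsewhere as well, so no single step separates it from either compound, and its value shows only where a doubly changed compound lands. The step from compound 2 to compound 3 is therefore expected to be modest, estimated as a 1.8-fold lower number from compound 2 to compound 3 (0.26 log units; within the scatter), leaning toward a lower number rather than a higher one. In this assay compound 3 is expected to give about 550 nM, within a range of 200 nM to 1500 nM.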

Compound 3, half-maximal inhibitory concentration: 1300 nM
Compound 3: the middle estimate sits 2.4-fold (0.37 log units) below what was measured, and the stated range covers the measured number.
By their numbers in this assay, from the lowest: compound 1; then compounds 2 and 3 (each within the scatter of the next).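

In this assay, fluoro in place of hydrogen on the fused ring system gives a 1.3-fold higher number from compound 2 to compound 3 (0.12 log units; within the scatter), so with methyl held constant at the other changed place, this swap produces no step beyond the scatter. With that fluoro held constant instead, methyl in place of fluoro on an aromatic carbon gives a 5.7-fold higher number from compound 1 to compound 3 (0.75 log units; beyond the scatter), and of these two steps only this one lies beyond the scatter. Nothing on hand gives a reason for the size of either step.

Going by these compounds, whether a chlorine, a methoxy group or an amine at the fused-ring position would also leave the number within the scatter remains open. So does whether adding the fused-ring fluoro would give an equally small step in a compound carrying fluoro rather than methyl at the other place.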